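Adding a Chloro to Compound 3

This account rests on a few compounds, and the source may have more. Where it says the series, first, only, none or still open, it means among the compounds named here.

Compound 3 `Cc1nc(-c2ccccc2)sc1C(=O)CSc1nc(-c2cccc(Cl)c2)c(C#N)c(=O)[nH]1` gives 10% in a functional assay on U-87MG ATCC cells for antiproliferative activity against U-87 MG (Homo sapiens), read by MTT assay, with a stated time of 48 h, tested at 100 uM (a higher number here means a weaker effect of the compound at the concentration tested, a lower number a stronger effect), the second highest of the three numbers shown, though every gap among them lies within the usual scatter. Compound 2 `COc1cccc(-c2nc(SCC(=O)c3sc(-c4ccc(Cl)cc4)nc3C)[nH]c(=O)c2C#N)c1` gives 8.54%, and compound 1 `COc1ccc(-c2nc(SCC(=O)c3sc(-c4ccc(Cl)cc4)nc3C)[nH]c(=O)c2C#N)cc1` gives 16.6%. Going by the values given here, the only measured step, a number 8.1 percentage points lower from compound 1 to compound 2 (within the scatter), moves a methoxy group and does not resemble the change now considered. Compound 4 `Cc1nc(-c2ccc(Cl)cc2)sc1C(=O)CSc1nc(-c2cccc(Cl)c2)c(C#N)c(=O)[nH]1` differs from compound 3 by chloro in place of hydrogen on an aromatic carbon. Among the compounds with values here, no measured pair isolates this change, and the three numbers so far all sit within scatter of one another, so no step beyond the scatter is expected. Compound 4 is therefore expected to give about 10%, within a range from 3% to 20%. The expected step of no change at the digits printed from compound 3 to compound 4 (within the scatter) is small.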

Compound 4, a percentage reported as activity, at one concentration (the size of the read-out at that concentration, not a potency): 12.5%
For compound 4 the middle estimate is 2.5 percentage points below the measured one; measured number inside the range.
By their numbers in this assay, from the lowest: compounds 2, 3, 4 and 1 (each within the scatter of the next).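

In this assay, going by these compounds alone, going from phenyl to 4-chlorophenyl gives the first reading of this change at this position: a number 2.5 percentage points higher from compound 3 to compound 4 (within the scatter). The swaps on the other aromatic ring, chloro in place of methoxy with a number 4 percentage points higher from compound 2 to compound 4 (within the scatter) and 3-chlorophenyl in place of 4-methoxyphenyl with a number 4.1 percentage points lower from compound 1 to compound 4 (within the scatter), also leave the read-out unresolved. Nothing available explains these results.

The compounds shown leave open whether a different group at this para position, such as an amine or a carboxylic acid, would give a step beyond the scatter.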